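From 4-methylphenoxy to 4-ethylphenoxy at the assay limit

The source may hold more compounds than are shown below. What is called first, only, known or untested is meant among the compounds shown, and "the series" means these compounds.

Compound 1 `COc1cc2c(cc1OC)CN(CCn1cc(COc3ccc([N+](=O)[O-])cc3)nn1)CC2`: > 100000 nM
Compound 2 `COc1cc2c(cc1OC)CN(CCn1cc(COc3ccc(C)cc3)nn1)CC2`: > 100000 nM

The measure here is an ADME assay on K562/A02 cells (Homo sapiens) for cytotoxicity, read by MTT assay, with a stated time of 48 h; a lower number here means a stronger inhibitor, a higher number a weaker inhibitor. In it, compound 1 gives > 100000 nM, which is a limit and not a number. Compound 2 gives > 100000 nM, again a limit, so its true value is not known. Among the measured compounds shown here, the only measured step is a step that the two limits leave unreadable from compound 1 to compound 2, with methyl in place of nitro on an aromatic carbon. It offers no size to carry forward, and the evidence amounts to the limit of > 100000 nM in this assay, at which 2 of the 2 values shown sit.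

Compound 3 `CCc1ccc(OCc2cn(CCN3CCc4cc(OC)c(OC)cc4C3)nn2)cc1` turns the methyl of compound 2 into an ethyl, with this difference: methyl in place of hydrogen on a saturated chain carbon bound to an aromatic carbon. In words, a methyl takes the place of a hydrogen on a saturated chain carbon bound to an aromatic carbon. For the measured compounds named here, no measured step shows the size of such a change, so no shift beyond the scatter is expected in this assay, and another limit is the likeliest report. The expected step is a step that the limit leaves unreadable from compound 2 to compound 3. For compound 3 the estimate is 120000 nM, with an expected range from 50000 nM to 300000 nM.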

Compound 3, half-maximal inhibitory concentration: > 100000 nM
Compound 3: a limit, no number (the forecaster's own chance of this, stated with the estimate: 80%); the middle value does not contradict the limit.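

In this assay compound 3 gives > 100000 nM, which is a limit and not a number. The steps among compound 1, compound 2 and compound 3 therefore cannot be read. The compounds shown leave open the true strength of each and whether nitro, methyl or ethyl makes any difference, with only this to go on: the limit of > 100000 nM in this assay, at which 3 of the 3 values shown sit.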